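Arylpiperazine replacement on a 5-HT6 ligand

A few compounds are considered here, and "the series" means these few. Any claim that something is new, unique, unknown or untested is made for them only; others in the source may bear on it.

Measured so far:
compound 1 `O=c1n(CCCCCCN2CCN(c3cccc(Cl)c3Cl)CC2)nc2ccccn12`: 299 nM
compound 2 `NC(=O)NCCCCCCN1CCN(c2cccc(Cl)c2)CC1`: 4930 nM

In an assay on HEK293 cells for displacement of a labelled ligand from 5-hydroxytryptamine receptor 6 (Homo sapiens), read by radioligand binding (on this read-out higher numbers stand for weaker inhibition and lower numbers for stronger inhibition), compound 1 gives 299 nM, the lower of the two numbers; compound 2 gives 4930 nM, a gap beyond the scatter. Compound 3 `O=c1n(CCCCCCN2CCN(c3cccc4c3OCCO4)CC2)nc2ccccn12` has not yet been measured. It differs from compound 1 in one place: 2,3-dihydro-1,4-benzodioxin-5-yl in place of 2,3-dichlorophenyl on an amine nitrogen in a ring. Among the measured compounds shown here, no measured pair reports this change, so the size of the step is unknown; a modest rise in the number, at or just beyond the scatter, is expected, giving a 1.8-fold higher number from compound 1 to compound 3 (0.26 log units; within the scatter). Compound 3 is therefore estimated at 550 nM, within 120 nM to 2500 nM.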

Compound 3, inhibition constant: 2840 nM
Compound 3: middle estimate off by 5.2-fold (0.71 log units), on the low side; the measured number lies above the stated range.
By their numbers in this assay, from the lowest: compound 1; then compounds 3 and 2 (each within the scatter of the next).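

In this assay, among the compounds shown here, putting 2,3-dihydro-1,4-benzodioxin-5-yl in place of 2,3-dichlorophenyl on an amine nitrogen in a ring gives a 9.5-fold higher number from compound 1 to compound 3 (0.98 log units; beyond the scatter), the only reading of this position with the rest of the molecule held constant. It shows that this position is sensitive to the group it carries, and that these two groups are not interchangeable here. Nothing measured accounts for the size of this step. From the compounds shown here alone, it remains open whether a plain phenyl or a methoxyphenyl on the same nitrogen would stand nearer compound 1 or compound 3. Going by these compounds, whether the step holds with a shorter chain is also open.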